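This account rests on a few compounds, and the source may have more. Where it says the series, first, only, none or still open, it means among the compounds named here.

Measured so far:
compound 1 `CCOC(=O)c1sc(-c2cccc(NC(=O)c3ccc(C(C)(C)C)cc3)c2)nc1Nc1ccc(N2CCN(C)CC2)cc1` — 21.2%
compound 2 `CCOC(=O)c1sc(-c2cccc(NC(=O)c3ccc(Cl)cc3)c2)nc1Nc1ccc(N2CCN(C)CC2)cc1` — 46.9%

In a functional assay on Ramos cells (Homo sapiens) for antiproliferative activity, read by CCK-8 assay, with a stated time of 72 h, tested at 40 uM (on this read-out higher numbers stand for more inhibition at the one concentration tested (going by the name of the read-out) and lower numbers for less inhibition), compound 2 gives 46.9%, the higher of the two numbers shown; compound 1 gives 21.2%. For the measured compounds named here, the one measured step, a number 25.7 percentage points higher from compound 1 to compound 2 (beyond the scatter), is the only guide available. Compound 3 `CCOC(=O)c1sc(-c2cccc(NC(=O)[C@H]3CC[C@H](C)CC3)c2)nc1Nc1ccc(N2CCN(C)CC2)cc1` differs from compound 2 by 4-methylcyclohexyl in place of 4-chlorophenyl on a carbonyl carbon. Going by the values given here, no measured step swaps the aromatic ring itself for a non-aromatic one, so this step only loosely bears on the change; the nearest comparison is that a bulkier carbon substituent on the aromatic carbon, as in compound 1, sat lower than the chloro of compound 2. On that basis the step of a number 16.9 percentage points lower from compound 2 to compound 3 (beyond the scatter) is expected to point downward, modest in size, though the direction is uncertain. Compound 3 is therefore estimated at 30%, with a range from 10% to 55%.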

Compound 3, a percentage reported as inhibition, at one concentration (the size of the read-out at that concentration, not a potency): 19.9%
For compound 3 the middle estimate is 10.1 percentage points above the measured one, and the stated range covers the measured number.
By their numbers in this assay, from the lowest: compounds 3 and 1 (each within the scatter of the next); then compound 2.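

In this assay, compound 3 alone among the compounds shown carries a non-aromatic ring on this carbonyl carbon, and replacing 4-chlorophenyl with 4-methylcyclohexyl gives a number 27 percentage points lower from compound 2 to compound 3 (beyond the scatter). Replacing 4-(tert-butyl)phenyl with the same group gives a number 1.3 percentage points lower from compound 1 to compound 3 (within the scatter), so the aromatic ring alone does not set compound 2 apart, since compound 1 also has one and compound 3 matches it without one. No evidence is available on what lies behind this difference.

The compounds shown leave open whether the chlorine alone sets compound 2 apart or whether it must sit on an aromatic ring, a question that unsubstituted phenyl, 4-fluorophenyl or 4-chlorocyclohexyl would bear on. They also leave open how a piperidine ring or a carboxylic acid at this place would read.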